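The compounds below may be only part of what the source reports. "The series", "measured", "known", "first", "only" and "open" are said of these compounds alone.

Compound 1 `CCCC(=O)Nc1c(C(O)(C(F)(F)F)C(F)(F)F)ccc2ccccc12`: 131 nM
Compound 2 `Cc1cccc(C(=O)Nc2c(C(O)(C(F)(F)F)C(F)(F)F)ccc3ccccc23)c1`: 23 nM
Compound 3 `O=C(Nc1c(C(O)(C(F)(F)F)C(F)(F)F)ccc2ccccc12)c1ccc(C(F)(F)F)cc1`: 160 nM

All three numbers come from an assay on LtK cells with ATP-sensitive inward rectifier potassium channel 11 (Homo sapiens) as the target; a lower number here means that less compound is needed, a higher number that more compound is needed for the effect. Compound 3 gives the highest number of the three. Its nearest neighbour is compound 1, with a 1.2-fold higher number from compound 1 to compound 3 (0.09 log units; within the scatter); its furthest is compound 2, with a 7.0-fold higher number from compound 2 to compound 3 (0.84 log units; beyond the scatter).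

Compound 4 `COc1ccc(C(=O)Nc2c(C(O)(C(F)(F)F)C(F)(F)F)ccc3ccccc23)cc1` is the next compound, and the change is methoxy in place of trifluoromethyl on an aromatic carbon. For the measured compounds named here, only one measured step alters the group on the ring attached to the carbonyl, and that is a 7.0-fold higher number from compound 2 to compound 3 (0.84 log units; beyond the scatter), a modest step. Going by the values given here, no measured step exchanges one group for another on the same aromatic carbon, so the direction of this change is uncertain. Compound 4 is therefore expected at 90 nM, within 30 nM to 300 nM, and the expected step is a 1.8-fold lower number from compound 3 to compound 4 (0.25 log units; within the scatter).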

Compound 4, half-maximal effective concentration: 417 nM
Compound 4: middle estimate off by 4.6-fold (0.67 log units), on the low side; the whole stated range lies below it.
By their numbers in this assay, from the lowest: compound 2; then compounds 1 and 3 (each within the scatter of the next); then compound 4.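

In this assay, for the compounds shown here, this is the first exchange of one group for another on this aromatic carbon, and methoxy in place of trifluoromethyl gives a step beyond the scatter: a 2.6-fold higher number from compound 3 to compound 4 (0.42 log units; beyond the scatter). The 4-methoxyphenyl amide also sits apart from the propyl and 3-methylphenyl amides, with a 3.2-fold higher number from compound 1 to compound 4 (0.50 log units; beyond the scatter) and an 18-fold higher number from compound 2 to compound 4 (1.26 log units; beyond the scatter). No measurement shown here accounts for this difference.

Still open, as far as these compounds go, is how an amine or a chlorine on this aromatic carbon would compare. From the compounds shown here alone, a chain longer than propyl on the carbonyl carbon also remains open.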